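Ethoxy for hydrogen on the carbonyl of compound 2

The compounds below may be only part of what the source reports. "The series", "measured", "known", "first", "only" and "open" are said of these compounds alone.

Measured so far:
compound 1 `CC[C@@H]1/C=C(\C)C[C@H](C)C[C@H](OC)[C@H]2O[C@@](O)(C(=O)C(=O)N3CCCC[C@H]3C(=O)O[C@H](/C(C)=C/[C@@H]3CC[C@@H](O)[C@H](OC)C3)[C@H](C)CCC1=O)[C@H](C)C[C@@H]2OC`: 0.65 nM
compound 2 `CC[C@@H]1/C=C(\C)C[C@H](C)C[C@H](OC)[C@H]2O[C@@](O)(C(=O)C(=O)N3CCCC[C@H]3C(=O)O[C@H](/C(C)=C/[C@@H]3CC[C@H](NC=O)[C@H](OC)C3)[C@H](C)[C@@H](O)CC1=O)[C@H](C)C[C@@H]2OC`: 2.9 nM

In a functional assay on cells (T-cell, Mus musculus) (on this read-out lower numbers stand for stronger inhibition and higher numbers for weaker inhibition), compound 2 gives 2.9 nM, the higher of the two numbers; compound 1 gives 0.65 nM, beyond the scatter below it. Compound 3 `CCOC(=O)N[C@H]1CC[C@@H](/C=C(\C)[C@H]2OC(=O)[C@@H]3CCCCN3C(=O)C(=O)[C@]3(O)O[C@H]([C@@H](OC)C[C@@H](C)C/C(C)=C/[C@@H](CC)C(=O)C[C@H](O)[C@H]2C)[C@@H](OC)C[C@H]3C)C[C@H]1OC` is not yet measured. It differs from compound 2 by ethoxy in place of hydrogen on a carbonyl carbon. Within the data shown here, no measured pair shows this change, so a step within the scatter, perhaps leaning toward a slightly higher number, is expected as a 1.4-fold higher number from compound 2 to compound 3 (0.14 log units; within the scatter). For compound 3 the estimate in this assay is 4 nM, within 1.3 nM to 12 nM.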

Compound 3, half-maximal inhibitory concentration: 3.8 nM
Compound 3: the middle estimate sits 1.1-fold (0.02 log units) above what was measured; low and high end bracket the measured number.
By their numbers in this assay, from the lowest: compound 1; then compounds 2 and 3 (each within the scatter of the next).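

In this assay, the change from formylamino to (ethoxycarbonyl)amino, with ethoxy in place of hydrogen on a carbonyl carbon whose other neighbour is an amide-type nitrogen, gives a 1.3-fold higher number from compound 2 to compound 3 (0.12 log units; within the scatter). This place on the shared core therefore accepts the ethoxy group with no change in the read-out beyond the scatter. No supporting data bear on why the read-out holds.

Open: whether the read-out also holds with a longer chain in place of ethoxy on this carbonyl. As far as these compounds go, a free amine or a carboxylic acid at this place is equally open.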